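Epimer of a Peroxide Ester Beyond the Assay Limit

The compounds below may be only part of what the source reports. "The series", "measured", "known", "first", "only" and "open" are said of these compounds alone.

Three peroxide-containing compounds have been tested in a functional assay on A549 cells (Homo sapiens) for cytotoxicity, read by colony formation; a lower number here means a stronger inhibitor of growth, a higher number a weaker inhibitor of growth. Compound 1, `C=C1CCC[C@@H]2[C@@H](CC[C@@]3(C)CC[C@H]([C@H](C)C(=O)O)OO3)[C@H](C)CC[C@@]12C`, the free acid of the series, gives 940 nM in this assay. Compound 2, `C=C1CCCC(C)(C)C1CC[C@]1(C)CC[C@H]([C@@H](C)C(=O)OC)OO1`, a methyl ester with a different carbocyclic portion, gives 640 nM. These two numbers lie within the scatter of each other, so no order between them is claimed.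

Compound 3, `C=C1CCCC(C)(C)C1(O)CC/C(C)=C/CC[C@]1(C)CC[C@H]([C@@H](C)C(=O)OC)OO1`, carries an unsaturated chain and a hydroxyl on its carbocycle; in this assay compound 3 reaches only > 5000 nM, which is a limit of the assay and not a number. Where compound 3 stands is thus described by the limit of > 5000 nM in this assay, at which 1 of the 3 values shown sits. Among the measured compounds shown here, no two compounds differ in a single place, so no measured step is available to calibrate anything.

Compound 4, `C=C1CCCC(C)(C)C1(O)CC/C(C)=C/CC[C@]1(C)CC[C@@H]([C@@H](C)C(=O)OC)OO1`, differs from compound 3 as follows: the two compounds have the same atoms and bonds; at least one stereo element is drawn with a configuration in one of them and without one in the other: 1 of 5 stereo elements differ; a stereocentre at a saturated ring carbon is drawn R in compound 3 and S in compound 4. Since compound 3 shows only a limit, the step cannot be sized against any measured pair. The account expects the inversion at this stereocentre to leave growth inhibition weak, with an expected step of a number no higher from compound 3 to compound 4 (the limit leaves the size open). For compound 4 the estimate in this assay is 5000 nM, within a range from 1500 nM to 15000 nM, and it is thought likely that only a limit is again reported.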

Compound 4, concentration for 50% growth inhibition: > 5000 nM
Compound 4: only a limit was reported (the forecaster's own chance of this, stated with the estimate: 60%); the middle value sits exactly at the limit.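

Compound 3 and compound 4 each reach only a limit in this assay and not a number, so the step between them cannot be read: the limit of > 5000 nM in this assay, at which 2 of the 4 values shown sit. What the compounds shown leave open is whether the inversion at this saturated ring carbon changes growth inhibition at all, and how far either compound lies past that limit.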